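This account rests on a few compounds, and the source may have more. Where it says the series, first, only, none or still open, it means among the compounds named here.

Three compounds that share one core and differ only in the side chain on the amino-acid part have been tested in a functional assay on the whole organism (Tail, strain ICR) with Mus musculus as the target, in the tail flick test, with a stated time of 90 min, at a dose of 25 umol/kg by the oral route; on this read-out lower numbers stand for a weaker effect and higher numbers for a stronger effect at the one dose given. Compound 1, `NC(=O)C[C@H](NC(=O)CN(c1nc(Cl)nc2[nH]cnc12)C1CC1)C(=O)O`, gives 20.1% in this assay. Compound 2, `CC(C)[C@H](NC(=O)CN(c1nc(Cl)nc2[nH]cnc12)C1CC1)C(=O)O`, gives 30.3% in this assay. Compound 3, `CC(C)C[C@H](NC(=O)CN(c1nc(Cl)nc2[nH]cnc12)C1CC1)C(=O)O`, gives 27% in this assay. The only step among these three that goes beyond the usual scatter is a number 10.2 percentage points lower from compound 2 to compound 1 (beyond the scatter), which comes with the change (carbamoylmethyl in place of isopropyl on a saturated chain carbon bound to an amide-type nitrogen and a carbonyl carbon). By contrast, a number 3.3 percentage points lower from compound 2 to compound 3 (within the scatter) and a number 6.9 percentage points higher from compound 1 to compound 3 (within the scatter) stay within the scatter, so nothing can be said about an order between compound 2 and compound 3 or between compound 1 and compound 3.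

Compound 4, `NC(=O)CC[C@H](NC(=O)CN(c1nc(Cl)nc2[nH]cnc12)C1CC1)C(=O)O`, has not yet been measured in this assay. It arises from compound 3 through the change (carbamoylmethyl in place of isopropyl on a saturated chain carbon, two bonds along the chain from an amide-type nitrogen and a carbonyl carbon). This is the same kind of change that turned compound 2 into compound 1, but not the same change: there it sat on a saturated chain carbon bound to an amide-type nitrogen and a carbonyl carbon, while here it sits one carbon further along the chain, two bonds from that nitrogen and carbonyl carbon. The cores of the two starting points also differ, by isobutyl in place of isopropyl on a saturated chain carbon bound to an amide-type nitrogen and a carbonyl carbon.

Resting on the modest drop seen in a number 10.2 percentage points lower from compound 2 to compound 1 (beyond the scatter), a step of about a number 7 percentage points lower from compound 3 to compound 4 (within the scatter) is expected for compound 4, with wide uncertainty given the single precedent. Compound 4 is therefore estimated to give around 20% in this assay, most plausibly between 8% and 32%.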

Compound 4, a percentage reported as activity, at one dose (the size of the read-out at that dose, not a potency): 41.1%
Beside the measured number, compound 4's estimate is 21.1 percentage points below it; measured number above the stated range.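

In this assay, the swap of isopropyl for carbamoylmethyl did not carry over from one core to the other, and even the direction of the step reversed: the same change on two cores in this assay, a number 10.2 percentage points lower (beyond the scatter) from compound 2 to compound 1 and a number 14.1 percentage points higher (beyond the scatter) from compound 3 to compound 4, 24.3 percentage points apart, beyond the scatter of two such steps

Compound 4 stands clear of all the other compounds, with a number 14.1 percentage points higher from compound 3 to compound 4 (beyond the scatter), a number 10.8 percentage points higher from compound 2 to compound 4 (beyond the scatter) and a number 21 percentage points higher from compound 1 to compound 4 (beyond the scatter), so it gives the strongest effect of these four at the one dose tested. This shows that a step seen on one core in this series cannot simply be assumed on another, but it rests on a single pair of steps, and because the change sits at different places on the chain in the two cases, the pair does not show what sets the direction.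

On these data alone, it remains open whether the higher number for compound 4 depends on the carbamoyl group at the end of its 2-carbamoylethyl chain or mainly on the length of that chain. A carboxylic acid or an amine at the end of the same chain, or a longer chain ending in a carbamoyl group, would help separate these two readings.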